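From 4-cyanophenyl to 3-bromophenyl on the shared core

The compounds below may be only part of what the source reports. "The series", "measured", "known", "first", "only" and "open" are said of these compounds alone.

Measured so far in a functional assay on SGC-7901 cells (Homo sapiens) for antiproliferative activity, read by sulforhodamine B assay, with a stated time of 72 h; a lower number here means a stronger inhibitor, a higher number a weaker inhibitor:
Compound 1 (`COc1ccccc1NC(=S)N/N=C/c1ccc2ccccc2n1`) gives > 100000 nM (a limit, not a number)
Compound 2 (`Cc1cccc(NC(=S)N/N=C/c2ccc3ccccc3n2)c1`) gives > 100000 nM (a limit, not a number)
Compound 3 (`N#Cc1ccc(NC(=S)N/N=C/c2ccc3ccccc3n2)cc1`) gives 23700 nM (a number)

Going by the values given here, compound 3 holds the only number of the three. Compound 1 and compound 2 both stand at the limit of > 100000 nM in this assay, at which 2 of the 3 values shown sit (a limit for each). Compound 4 (`S=C(N/N=C/c1ccc2ccccc2n1)Nc1cccc(Br)c1`) departs from compound 3 by one change, 3-bromophenyl in place of 4-cyanophenyl on an amide-type nitrogen. Among the compounds with values here, two measured steps bear on it, both beyond the scatter and both bringing in 4-cyanophenyl: (an at least 4.2-fold lower number from compound 1 to compound 3 (0.62 log units; beyond the scatter)) and (an at least 4.2-fold lower number from compound 2 to compound 3 (0.62 log units; beyond the scatter)). Each starts from a limit, so neither shows its full size. Losing that group is therefore expected to raise the number in this assay by a moderate step (a 2.1-fold higher number from compound 3 to compound 4 (0.32 log units; beyond the scatter)). For compound 4 the estimated value is 50000 nM (expected range 10000 nM to 100000 nM).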

Compound 4, half-maximal inhibitory concentration: 78600 nM
The estimate for compound 4 lay 1.6-fold (0.20 log units) below the measured number; measured number inside the range.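

In this assay, going by these compounds alone, the change from 4-cyanophenyl to 3-bromophenyl on the amide-type nitrogen gives the first step at this position with both ends measured as numbers (a 3.3-fold higher number from compound 3 to compound 4 (0.52 log units; beyond the scatter)). The steps from the other two groups show only floors (an at least 1.2-fold lower number from compound 2 to compound 4 (0.10 log units; that floor lies within the scatter)) and (an at least 1.2-fold lower number from compound 1 to compound 4 (0.10 log units; that floor lies within the scatter)). Neither 3-bromophenyl nor 3-methylphenyl can therefore be ranked against 2-methoxyphenyl, and those steps stop at a limit of the assay: (the limit of > 100000 nM in this assay, at which 2 of the 4 values shown sit).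

The compounds shown leave open whether 3-cyanophenyl would match 4-cyanophenyl. They also leave open how a phenyl ring carrying an amine or a carboxylic acid would read here.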